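A few compounds are considered here, and "the series" means these few. Any claim that something is new, unique, unknown or untested is made for them only; others in the source may bear on it.

Measured compounds:
compound 1, `CC1(C)CC12NC(=O)N(NC(=O)c1ccc(F)cc1)C2=O`: 100 mg/kg
compound 2, `CC1(C)CC12NC(=O)N(NC(=O)c1ccc([N+](=O)[O-])cc1)C2=O`: 300 mg/kg

In a functional assay on the whole organism (Hindlimb) for inhibition, with Mus musculus as the target, with a stated time of 0.5 h (on this read-out lower numbers stand for an effect already at smaller amounts and higher numbers for an effect only at larger amounts of compound), compound 1 gives 100 mg/kg and compound 2 gives 300 mg/kg. Among the compounds with values here, compound 2 stands highest of the two numbers; the only neighbour is compound 1, and the step of a 3.0-fold higher number from compound 1 to compound 2 (0.48 log units; beyond the scatter) places compound 2 beyond the scatter above it.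

Compound 3, `CN(C)c1ccc(C(=O)NN2C(=O)NC3(CC3(C)C)C2=O)cc1`, differs from compound 2 by dimethylamino in place of nitro on an aromatic carbon. Within the data shown here, no measured step exchanges nitro for dimethylamino; the one step that bears on a change at this place on the ring is a 3.0-fold higher number from compound 1 to compound 2 (0.48 log units; beyond the scatter), which was modest. It shows that exchanging the group at this place can move the number beyond the scatter, but gives no direction for the present exchange. A modest step of uncertain direction is therefore expected in this assay, most likely back toward the number of compound 1. Compound 3 is estimated at 200 mg/kg, in the range 100 mg/kg to 600 mg/kg, which means an expected step of a 1.5-fold lower number from compound 2 to compound 3 (0.18 log units; within the scatter).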

Compound 3, minimum effective dose: 300 mg/kg
Beside the measured number, compound 3's estimate is 1.5-fold (0.18 log units) below it; low and high end bracket the measured number.
By their numbers in this assay, from the lowest: compound 1; then compounds 2 and 3 (each within the scatter of the next).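

In this assay, dimethylamino in place of nitro on the aromatic carbon gives no change at the digits printed from compound 2 to compound 3 (within the scatter), so this read-out does not separate two groups of equal heavy-atom count that differ in their count of hydrogen-bond acceptors. Dimethylamino in place of fluoro gives a 3.0-fold higher number from compound 1 to compound 3 (0.48 log units; beyond the scatter), matching a 3.0-fold higher number from compound 1 to compound 2 (0.48 log units; beyond the scatter), so among these three compounds the separation at this place lies between fluoro on one side and nitro and dimethylamino on the other. Nothing measured here accounts for that grouping.

From the compounds shown here alone, it remains open whether a chlorine atom, a methoxy group or a carboxylic acid at this place would fall with compound 1 or with compounds 2 and 3. Also open, going by these compounds, is whether a hydrogen atom at this place would give a number different from that of compound 1.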